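Does the six-membered ring bring clearance back up?

This account rests on a few compounds, and the source may have more. Where it says the series, first, only, none or still open, it means among the compounds named here.

Within the data shown here, in an ADME assay (liver) for pharmacokinetics, with Liver microsome (Rattus norvegicus) as the target, read by LC-MS, using microsomes, tested at 2 uM (a higher number here means faster removal of the compound, a lower number slower removal), compound 2 (`C[C@](O)(CNC(=O)c1cnc(OCC2CC2)c(-c2ccc(Cl)cc2)c1)C1CC1`) gives 0.0024 mL/min/kg, the lower of the two numbers measured so far, while compound 1 (`O=C(N[C@@H]1CCCC[C@H]1O)c1cnc(OCC2CC2)c(-c2ccc(Cl)cc2)c1`) gives 0.064 mL/min/kg. Compound 3 (`O=C(N[C@@H]1CCCC[C@@H]1O)c1cnc(OCC2CC2)c(-c2ccc(Cl)cc2)c1`) has not yet been measured. The shared core stays the same, and only the group on the amide-type nitrogen differs: a group of 7 heavy atoms (6 carbon, 1 oxygen; one six-membered non-aromatic ring of carbon only) in place of a group of 7 heavy atoms (6 carbon, 1 oxygen; one three-membered non-aromatic ring of carbon only), on an amide-type nitrogen. The group that enters is 2-hydroxycyclohexyl.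

Among the measured compounds shown here, one measured step bears on this change. Compound 1 also has a six-membered non-aromatic ring of carbon only on the amide-type nitrogen, and replacing that group gave a 27-fold lower number from compound 1 to compound 2 (1.43 log units; beyond the scatter). For the measured compounds named here, compound 3 broadly reverses that replacement, although its ring is not an exact copy of the one in compound 1, and no measurement yet shows what that difference means. A single step is also thin evidence. A rise of similar size, beyond the scatter, is therefore expected in this assay, and the estimated change is a 21-fold higher number from compound 2 to compound 3 (1.32 log units; beyond the scatter). The expected value for compound 3 is 0.05 mL/min/kg, within an estimated range of 0.01 mL/min/kg to 0.25 mL/min/kg.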

Compound 3, clearance: 0.163 mL/min/kg
Estimate against measurement, compound 3: 3.3-fold (0.51 log units) below; the range from low to high includes it.
By their numbers in this assay, from the lowest: compound 2; then compound 1; then compound 3.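

Placing the 2-hydroxycyclohexyl group on the amide-type nitrogen gives a 68-fold higher number from compound 2 to compound 3 (1.83 log units; beyond the scatter) in this assay, so the high side of the earlier step now holds for a second drawn form of this ring and does not rest on compound 1 alone. The arrangement within the ring also matters at this position, though much less than the swap between the two groups: changing the drawn configuration at one saturated ring carbon gives a 2.5-fold higher number from compound 1 to compound 3 (0.41 log units; beyond the scatter), which is modest but still beyond the scatter. This smaller gap can be assigned to configuration alone, and to no other structural change, because of one thing: the fact that compounds 1 and 3 differ only in the configuration as drawn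

The compounds shown do not separate the contribution of the six-membered ring from that of the other differences between the two groups, and a cyclohexyl group without the hydroxyl, or a 2-hydroxycyclopentyl group, would test that more directly. They also leave open whether the remaining stereo forms of the 2-hydroxycyclohexyl group would fall near compound 1 and compound 3, or well away from both.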